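The compounds below may be only part of what the source reports. "The series", "measured", "known", "first", "only" and "open" are said of these compounds alone.

In a functional assay on MKN-1 cells (Homo sapiens) for inhibition, read by sulforhodamine B assay, with a stated time of 48 h (a lower number here means a stronger inhibitor of growth, a higher number a weaker inhibitor of growth), compound 2 `COc1ccc(C2([C@H]3C[C@H](n4cc(C)c(=O)[nH]c4=O)O[C@@H]3CO[Si](C)(C)C(C)(C)C)SCCCS2)cc1OC` gives 2290 nM. For compound 1 `Cc1cn([C@H]2C[C@H](CC3=CC(=O)C(=O)C=C3)[C@@H](CO[Si](C)(C)C(C)(C)C)O2)c(=O)[nH]c1=O` the entry reads no result reported. This leaves one number available, so compound 2 cannot yet be ranked against any other compound. Compound 3 `COc1ccc(C2([C@H]3C[C@@H](n4cc(C)c(=O)[nH]c4=O)O[C@@H]3CO[Si](C)(C)C(C)(C)C)SCCCS2)cc1OC` has still to be measured. Its relation to compound 2 is a narrow one: the two compounds have the same atoms and bonds and differ only in configuration as drawn: 1 of 3 stereo elements differ; a stereocentre at a saturated ring carbon is drawn R in compound 2 and S in compound 3. The atoms and bonds are the same, and a stereocentre at a saturated ring carbon is drawn R in compound 2 and S in compound 3. Among the compounds with values here, no measured pair shows what such an inversion does in this assay, so the expectation rests on compound 2 alone, at 2290 nM. No shift beyond the scatter is expected, and the uncertainty runs in both directions. The estimated change is a 1.2-fold higher number from compound 2 to compound 3 (0.09 log units; within the scatter). Compound 3 is expected at 2800 nM, within an estimated range of 1000 nM to 9000 nM.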

Compound 3, concentration for 50% growth inhibition: 5010 nM
Beside the measured number, compound 3's estimate is 1.8-fold (0.25 log units) below it; measured number inside the range.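

In this assay the inversion at the saturated ring carbon gives the first step that can be read among these compounds: a 2.2-fold higher number from compound 2 to compound 3 (0.34 log units; beyond the scatter) is a modest change, but it lies beyond the scatter. Of this pair, compound 2, with the stereocentre drawn R, is the stronger inhibitor of growth, so the drawn configuration at this carbon matters even with every atom and bond unchanged. The step can be assigned to this one stereocentre because nothing else separates the pair: the fact that compounds 2 and 3 differ only in the configuration as drawn

Within the data shown here, whether the same inversion would have a similar effect in other compounds remains open, as this is the only such pair with numbers. Also open, going by these compounds, is how a free hydroxyl group or a carboxylic acid in place of the silyl ether would alter the number in this assay for either configuration.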